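The source may hold more compounds than are shown below. What is called first, only, known or untested is meant among the compounds shown, and "the series" means these compounds.

Of the compounds shown here, three have been measured in a toxicity assay on the whole organism (J774 cells) for cytotoxicity, with Mus musculus as the target, read by MTT assay, with a stated time of 24 h, tested at 10 uM; a higher number here means a weaker effect of the compound at the concentration tested, a lower number a stronger effect. Compound 1 `C=CCO[C@H]1O[C@H](CN)[C@@H](OCc2ccc3ccccc3c2)[C@H](OCc2ccc3ccccc3c2)[C@H]1N` gives 86.9%. Among the measured compounds shown here, compound 2 `NC[C@H]1O[C@H](O[C@H]2[C@H](O)[C@@H](O)[C@H](N)C[C@@H]2N)[C@H](N)[C@@H](OCCCc2ccc3ccccc3c2)[C@@H]1OCCCc1ccc2ccccc2c1` gives 87.7%, a number that lies within the usual scatter of the one for compound 1. Compound 3 `C=CCO[C@H]1O[C@H](CN)[C@@H](OCCCc2ccc3ccccc3c2)[C@H](OCCCc2ccc3ccccc3c2)[C@H]1N` gives 105%. The change from compound 3 to compound 2 is 4,6-diamino-2,3-dihydroxycyclohexyl in place of allyl on an oxygen on a saturated carbon and it made a step of a number 17.3 percentage points lower from compound 3 to compound 2 (beyond the scatter). Compound 4 `NC[C@H]1O[C@H](O[C@H]2[C@H](O)[C@@H](O)[C@H](N)C[C@@H]2N)[C@H](N)[C@@H](OCc2ccc3ccccc3c2)[C@@H]1OCc1ccc2ccccc2c1` has not yet been measured; it arises from compound 1 by the same kind of change at the same place, (4,6-diamino-2,3-dihydroxycyclohexyl in place of allyl on an oxygen on a saturated carbon). How the core of compound 1 differs from that of compound 3 is not broken down here. Because the same change already gave a number 17.3 percentage points lower from compound 3 to compound 2 (beyond the scatter), a step of similar size is expected here, a number 14.9 percentage points lower from compound 1 to compound 4 (beyond the scatter). Compound 4 is therefore estimated at about 72%, most likely between 55% and 90%.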

Compound 4, a percentage reported as activity, at one concentration (the size of the read-out at that concentration, not a potency): 79.1%
Compound 4: the middle estimate sits 7.1 percentage points below what was measured, and the stated range covers the measured number.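

In this assay the swap of allyl for 4,6-diamino-2,3-dihydroxycyclohexyl gives a number 7.8 percentage points lower from compound 1 to compound 4 (within the scatter) and so cannot, on its own, be told apart from the scatter of repeated measurements. Set beside the step on the other core, the size of the change does not measurably depend on the core: the same change on two cores in this assay, a number 17.3 percentage points lower (beyond the scatter) from compound 3 to compound 2 and a number 7.8 percentage points lower (within the scatter) from compound 1 to compound 4, 9.5 percentage points apart, within the scatter of two such steps. Among the compounds shown here, with only two pairs, this does not show that the change would behave alike on every core, nor that it truly lowers the number on the core of compound 1.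

Still open, as far as these compounds go, is what a simple amine, a carboxylic acid or a longer chain would do in place of allyl on that oxygen.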